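A few compounds are considered here, and "the series" means these few. Any claim that something is new, unique, unknown or untested is made for them only; others in the source may bear on it.

Measured compounds in the series so far:

compound 1 `CC(=O)N1CC=C(c2ccn3c(-c4ccc(NC(=O)c5ccc([N+](=O)[O-])o5)cc4)cnc3c2)CC1`, 410 nM
compound 2 `O=C(Nc1ccc(-c2cnc3ccccn23)cc1)c1ccc([N+](=O)[O-])o1`, 360 nM
compound 3 `COc1ccn2c(-c3ccc(NC(=O)c4ccc([N+](=O)[O-])o4)cc3)cnc2c1`, 720 nM

In a functional assay on AGS cells (Homo sapiens) for antiproliferative activity, read by CCK-8 assay, with a stated time of 72 h (on this read-out lower numbers stand for stronger inhibition and higher numbers for weaker inhibition), compound 2 gives 360 nM, the low end of a cluster in which all three numbers lie within the scatter of one another: a 1.1-fold lower number from compound 1 to compound 2 (0.06 log units; within the scatter), a 2.0-fold higher number from compound 2 to compound 3 (0.30 log units; within the scatter), and between the other pair a 1.8-fold higher number from compound 1 to compound 3 (0.24 log units; within the scatter). Every measured step alters the substituent on the shared core and none moves the read-out beyond the scatter.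

Compound 4 `Cc1cc(-c2cnc3ccccn23)ccc1NC(=O)c1ccc([N+](=O)[O-])o1` is not yet measured in this assay. Relative to compound 2 it shows (methyl in place of hydrogen on an aromatic carbon), on an aromatic carbon of a six-membered aromatic ring of carbon only, ortho to a large group and meta to a group of 9 heavy atoms. For the measured compounds named here, no measured step touches that ring, so the three steps bear on it only indirectly, as a sign that this series tolerates small changes without leaving the scatter. The expected step is therefore a 1.1-fold higher number from compound 2 to compound 4 (0.05 log units; within the scatter), no clear direction. For compound 4 the estimate in this assay is 400 nM, in the range 150 nM to 1100 nM.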

Compound 4, half-maximal inhibitory concentration: 730 nM
For compound 4 the middle estimate is 1.8-fold (0.26 log units) below the measured one; the range from low to high includes it.
By their numbers in this assay, from the lowest: compounds 2, 1, 3 and 4 (each within the scatter of the next, the first and the last beyond it).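

In this assay, for the compounds shown here, methyl in place of hydrogen on an aromatic carbon of the six-membered aromatic ring of carbon only, ortho to a large group, gives a 2.0-fold higher number from compound 2 to compound 4 (0.31 log units; beyond the scatter), the only step at hand that lies beyond the scatter, though it is modest. Going by these compounds alone, this ring therefore does not share the tolerance suggested by the earlier steps: a single added carbon here leaves the scatter, whereas the group of 9 heavy atoms on the shared core, in a 1.1-fold lower number from compound 1 to compound 2 (0.06 log units; within the scatter), stayed within it. Nothing at hand gives a reason for this step.

The compounds shown leave open whether the rise in the number follows from the size of the group at this carbon or is specific to methyl. A fluorine atom, a methoxy group or an ethyl group on the same carbon would test this.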